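This account rests on a few compounds, and the source may have more. Where it says the series, first, only, none or still open, it means among the compounds named here.

Compound 1 `COC(=O)c1cccc(Nc2ncnc3ccc(NC(=O)Nc4ccc(CN5CCN(C)CC5)cc4)cc23)c1`: in a functional assay on A549 cells (Homo sapiens) for antiproliferative activity, read by MTT assay, with a stated time of 72 h (a higher number here means a weaker inhibitor, a lower number a stronger inhibitor), compound 1 gives > 10000 nM, a limit of the assay.
Compound 2 `CN1CCN(Cc2ccc(NC(=O)Nc3ccc4ncnc(Nc5cccc(C(=O)N6CCCC6)c5)c4c3)cc2)CC1`: in this assay compound 2 gives > 10000 nM, also a limit.
Compound 3 `O=C(Nc1ccc(CN2CCCC2)cc1)Nc1ccc2ncnc(Nc3cccc(C(F)(F)F)c3)c2c1`: in this assay compound 3 gives 830 nM.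

Within the data shown here, compound 3 is the only member with a number; the two others sit at the limit of > 10000 nM in this assay, at which 2 of the 3 values shown sit. The step that the two limits leave unreadable from compound 1 to compound 2 is therefore not readable in size.

Compound 4 `CN1CCN(CCNC(=O)Nc2ccc3ncnc(Nc4cccc(C(F)(F)F)c4)c3c2)CC1` differs from compound 3 by 2-(4-methylpiperazin-1-yl)ethyl in place of 4-((pyrrolidin-1-yl)methyl)phenyl on an amide-type nitrogen. Among the measured compounds shown here, no measured step touches this change, and the one step that is measured is unreadable, so no size can be taken over from it. Compound 4 is expected to be weaker than compound 3, with a 3.6-fold higher number from compound 3 to compound 4 (0.56 log units; beyond the scatter) as a rough guess; an estimate for compound 4 of 3000 nM, range 600 nM to 15000 nM, is expected.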

Compound 4, half-maximal inhibitory concentration: > 10000 nM
Compound 4: a limit, no number (the forecaster's own chance of this, stated with the estimate: 30%); at least 3.3-fold (0.52 log units) between middle value and limit.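

Among these compounds, on the amide-type nitrogen, 2-(4-methylpiperazin-1-yl)ethyl in place of 4-((pyrrolidin-1-yl)methyl)phenyl gives the first readable step in this assay, an at least 12-fold higher number from compound 3 to compound 4 (1.08 log units; beyond the scatter). Compound 4 gives > 10000 nM, a limit of the assay, so the group on this nitrogen can decide whether a number is obtained at all. Only compound 3 now carries a number: the limit of > 10000 nM in this assay, at which 3 of the 4 values shown sit.

The step between compound 1 and compound 2 cannot be read, so the groups on that carbonyl carbon stay uncompared. From the compounds shown here alone, whether a 2-(morpholin-4-yl)ethyl group on the same nitrogen would give a number remains open.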